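Phenyl in Place of Ethyl: Expecting a Small Step

A few compounds are considered here, and "the series" means these few. Any claim that something is new, unique, unknown or untested is made for them only; others in the source may bear on it.

The two measured compounds:

Compound 1, `CCCOC(=O)C1=C(C)NC(=O)NC1c1ccco1`, gives 2% in an assay on HeLa cells for displacement of a labelled ligand from adenosine receptor A3 (Homo sapiens), with a stated time of 180 min, tested at 10 uM; a lower number here means less inhibition, a higher number more inhibition at the concentration tested (going by the name of the read-out).
Compound 2, `CCOC(=O)C1=C(CC)NC(=O)NC1c1ccco1`, gives 3% in this assay.

Both numbers are small, meaning that at the tested concentration neither compound displaces much of the labelled ligand. Compound 2 shows the larger of the two numbers, but the value of compound 1 lies only slightly lower and within the scatter of repeated measurements, so the two cannot be told apart. Across compounds 1 and 2 only the ester chain changes, and the read-out does not move.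

Compound 3, `CCOC(=O)C1=C(c2ccccc2)NC(=O)NC1c1ccco1`, has not yet been measured. It differs from compound 2 in one place: phenyl in place of ethyl on a double-bonded ring carbon. Among the measured compounds shown here, no step between measured compounds involves this position, so there is no direct guide to what a phenyl group there will do. Given that both measured compounds sit close to zero, the expected outcome for compound 3 is a modest number, with any change from compound 2 most likely not beyond the scatter. The step of a number 5 percentage points higher from compound 2 to compound 3 (within the scatter) is therefore expected to be small. Compound 3 is estimated to give 8% in this assay, within a range from 0% to 25%.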

Compound 3, a percentage reported as inhibition, at one concentration (the size of the read-out at that concentration, not a potency): 2%
The estimate for compound 3 lay 6 percentage points above the measured number; the range from low to high includes it.
By their numbers in this assay, from the lowest: compounds 1, 3 and 2 (each within the scatter of the next).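

Phenyl in place of ethyl on the double-bonded ring carbon gives a number 1 percentage points lower from compound 2 to compound 3 (within the scatter) in this assay, which is the first direct reading at this position. Putting a six-membered aromatic ring of carbon where a ringless ethyl stood therefore leaves the read-out where it was, with compound 3 at 2% and still displacing little of the labelled ligand at the tested concentration. With all three numbers this close to zero, the result shows that this change brings no detectable gain, but it cannot show a loss, and nothing at hand explains the outcome.

Going by these compounds, it remains open whether an amine, a carboxylic acid or a longer chain on this ring carbon would lift the number beyond the scatter, or whether nothing placed here would do so. It is also unknown whether a group other than the furan-2-yl group, such as a phenyl ring at that place, would give a clearer read-out against which changes at this position could be judged.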